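A few compounds are considered here, and "the series" means these few. Any claim that something is new, unique, unknown or untested is made for them only; others in the source may bear on it.

Compound 1, `CCN1C(=O)CN(C2CCCC2)c2nc(Nc3ccc(OC)cc3)ncc21`: in a functional assay on HCT-116 cells (Homo sapiens) for inhibition, read by MTT assay, with a stated time of 48 h (on this read-out lower numbers stand for stronger inhibition and higher numbers for weaker inhibition), compound 1 gives 11000 nM.
Compound 2, `CC1CCN(c2ccc(Nc3ncc4c(n3)N(C3CCCC3)CC(=O)N4)cc2)CC1`: compound 2 gives 8430 nM.
Compound 3, `O=C1CN(C2CCCC2)c2nc(Nc3ccc(N4CCCCC4)cn3)ncc2N1`: for compound 3 only a limit is reported, > 30000 nM.

Compound 3 therefore stands apart from the other two measured compounds, its result being a limit of the assay and not a number, as recorded in the limit of > 30000 nM in this assay, at which 1 of the 3 values shown sits. Compound 4, `O=C1CN(C2CCCC2)c2nc(Nc3ccc(N4CCNCC4)cn3)ncc2N1`, has not yet been measured. It differs from compound 3 in one place: piperazin-1-yl in place of piperidin-1-yl on an aromatic carbon. No measured pair among these compounds makes exactly this exchange, so there is no measured step to lean on. With compound 3 sitting at a limit, a change of this kind is expected to leave the value in the same region, and the expected step is an at least 1.2-fold lower number from compound 3 to compound 4 (0.07 log units; that floor lies within the scatter), none beyond the usual scatter in either direction. Compound 4 is therefore estimated at 25000 nM, with a range from 8000 nM to 60000 nM, and a fair chance that this assay again reports only a limit.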

Compound 4, half-maximal inhibitory concentration: > 30000 nM
Compound 4: only a limit was reported; the forecaster's own chance of this, stated with the estimate: 45%; at least 1.2-fold (0.07 log units) between middle value and limit.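

Compound 3 and compound 4 each give only a limit and not a number, so no step can be read between them: the limit of > 30000 nM in this assay, at which 2 of the 4 values shown sit.
The compounds shown leave open whether piperazin-1-yl in place of piperidin-1-yl changes the result in this assay at all, and in which direction.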